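The source may report more compounds than this note shows. Statements on the series, on what has been measured and on what is new or still open speak of the compounds shown alone.

In a functional assay on the whole organism with Rattus norvegicus as the target (a higher number here means that more compound is needed for the effect, a lower number that less compound is needed), three compounds have been measured so far. Compound 1 (`CCOC(=O)C(=O)Nc1cccc(NC)c1C#N`) stands at 0.2 mg/kg and compound 2 (`CCCNc1cccc(NC(=O)C(=O)OCC)c1C#N`) at 0.5 mg/kg while compound 3 (`CCOC(=O)C(=O)Nc1cccc(N2CCCCC2)c1C#N`) has the highest number of the three at 2.2 mg/kg on this scale. Compound 4 (`CCOC(=O)C(=O)Nc1cccc(F)c1C#N`) is compound 3 with fluoro in place of piperidin-1-yl on an aromatic carbon, ortho to a cyano group (fluoro in place of piperidin-1-yl on an aromatic carbon).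

Within the data shown here, no measured step brings in fluoro, so there is no direct precedent. The closest evidence is the pair of steps that bring in piperidin-1-yl on this same carbon. The step of an 11-fold higher number from compound 1 to compound 3 (1.04 log units; beyond the scatter) is large and the step of a 4.4-fold higher number from compound 2 to compound 3 (0.64 log units; beyond the scatter) is modest, and both lie beyond the scatter. The step of a 2.5-fold higher number from compound 1 to compound 2 (0.40 log units; beyond the scatter) also raises the number as the group on this carbon grows. Among these three compounds, smaller groups go with lower numbers, and none goes against this. Removing piperidin-1-yl is therefore expected to lower the number by a modest step. Fluoro differs in kind from all three groups measured, so the range stays wide. In this assay the estimated step is a 3.1-fold lower number from compound 3 to compound 4 (0.50 log units; beyond the scatter) and it would count as modest. Compound 4 is expected at 0.7 mg/kg with an estimated range from 0.15 mg/kg to 3 mg/kg in the eventual measurement.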

Compound 4, dose for half-maximal effect: 1.2 mg/kg
Compound 4: middle estimate off by 1.7-fold (0.23 log units), on the low side, within the range that was stated.
By their numbers in this assay, from the lowest: compound 1; then compound 2; then compounds 4 and 3 (each within the scatter of the next).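

In this assay, replacing piperidin-1-yl with fluoro on this aromatic carbon, ortho to a cyano group, gives a 1.8-fold lower number from compound 3 to compound 4 (0.26 log units; within the scatter) and so leaves the two compounds indistinguishable, even though a group of 6 heavy atoms gives way to a single fluorine atom. Compound 4 goes against the earlier link between smaller groups and lower numbers, since fluoro gives a 2.4-fold higher number from compound 2 to compound 4 (0.38 log units; beyond the scatter) and a 6.0-fold higher number from compound 1 to compound 4 (0.78 log units; beyond the scatter) even though it is smaller than both groups it replaces. Heavy-atom count alone therefore does not order this position, and among the four compounds the two lower numbers belong to those carrying methylamino and propylamino, while fluoro and piperidin-1-yl stand together above them.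

No measured evidence shown here accounts for this ordering. The compounds shown leave open whether a plain amino group or dimethylamino would stand with methylamino and propylamino or with fluoro and piperidin-1-yl, and where chloro or methoxy would fall on this carbon.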